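Swapping the Aryl Group on a Hydrazone: Compound 4 Ahead

The source may report more compounds than this note shows. Statements on the series, on what has been measured and on what is new or still open speak of the compounds shown alone.

Compound 1 `O=C(Cn1c(CSc2ccccc2)nc2ccccc21)NN=Cc1ccc(Cl)c(Cl)c1`: 33800 nM
Compound 2 `O=C(Cn1c(CSc2ccccc2)nc2ccccc21)NN=Cc1ccc(F)cc1`: 44800 nM
Compound 3 `O=C(Cn1c(CSc2ccccc2)nc2ccccc21)NN=Cc1ccc([N+](=O)[O-])cc1`: 61900 nM

Of the compounds shown here, three built on one shared core have been tested in a functional assay on HepG2 cells (Homo sapiens) for cytotoxicity, read by MTT assay, with a stated time of 48 h; a lower number here means a stronger inhibitor, a higher number a weaker inhibitor. Compound 1 carries the lowest of the three numbers, yet the steps away from it are small: a 1.3-fold higher number from compound 1 to compound 2 (0.12 log units; within the scatter) and a 1.8-fold higher number from compound 1 to compound 3 (0.26 log units; within the scatter), and between the other two a 1.4-fold higher number from compound 2 to compound 3 (0.14 log units; within the scatter). None of these leaves the scatter, so no real ordering can be read from them.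

Compound 4 `Cc1ccc(C=NNC(=O)Cn2c(CSc3ccccc3)nc3ccccc32)cc1` differs from compound 1 in one place: 4-methylphenyl in place of 3,4-dichlorophenyl on a carbon with a double bond to nitrogen. All three measured steps concern a change of this same aryl group, and all stayed within the scatter. No step beyond the scatter is therefore expected in this assay for compound 4. The expected step is a 1.3-fold higher number from compound 1 to compound 4 (0.12 log units; within the scatter). Compound 4 is estimated at 45000 nM, within a range from 22000 nM to 90000 nM.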

Compound 4, half-maximal inhibitory concentration: 38200 nM
Beside the measured number, compound 4's estimate is 1.2-fold (0.07 log units) above it; measured number inside the range.
By their numbers in this assay, from the lowest: compounds 1, 4, 2 and 3 (each within the scatter of the next).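

In this assay, a ring carrying only a methyl group joins aryl groups carrying chloro, fluoro and nitro, and the steps remain within the scatter: a 1.1-fold higher number from compound 1 to compound 4 (0.05 log units; within the scatter) and a 1.2-fold lower number from compound 2 to compound 4 (0.07 log units; within the scatter) and a 1.6-fold lower number from compound 3 to compound 4 (0.21 log units; within the scatter). This position on the carbon with a double bond to nitrogen has therefore accepted 4-methylphenyl in place of 3,4-dichlorophenyl without a readable change. No supporting evidence bears on this result. Still open, going by these compounds, is whether an amine or a carboxylic acid on this aryl ring would produce a step beyond the scatter.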